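A Cyclohexyl Swap at the Assay Limit

A few compounds are considered here, and "the series" means these few. Any claim that something is new, unique, unknown or untested is made for them only; others in the source may bear on it.

Compound 1 `CO[C@H]1CC[C@H](NC(=O)c2n[nH]cc2NC(=O)c2ncoc2-c2ccccc2)CC1`: 28000 nM
Compound 2 `CO[C@H]1CC[C@H](NC(=O)c2n[nH]cc2NC(=O)c2ccc(N3CCCC3)cc2)CC1`: > 50000 nM (a limit of the assay, not a number)
Compound 3 `COc1cccc(OC)c1C(=O)Nc1c[nH]nc1C(=O)NCC1CCCCC1`: > 50000 nM (a limit of the assay, not a number)

These three results come from an ADME assay on MRC5 cells (Homo sapiens) for inhibition, with a stated time of 72 h; a higher number here means that more compound is needed for the effect, a lower number that less compound is needed. Compound 1 is the only one of the three with an actual number. Compound 3 sits at the limit of > 50000 nM in this assay, at which 2 of the 3 values shown sit. Compound 2 sits at that same limit, so the true value of neither compound is known.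

Compound 4 `COc1cccc(OC)c1C(=O)Nc1c[nH]nc1C(=O)NC1CCC(C)CC1` is the next compound to be tested, and it differs from compound 3 in one place. The difference is 4-methylcyclohexyl in place of cyclohexylmethyl on an amide-type nitrogen. In words, 4-methylcyclohexyl stands in place of cyclohexylmethyl on an amide-type nitrogen. The two compounds have the same atoms, joined differently.

Going by the values given here, no measured pair in this small set shows what such a swap does, so the closest guide is compound 3 itself. Compound 3 offers only a limit, > 50000 nM. No step beyond the usual scatter is expected in this assay, in either direction, and compound 4 will most likely be reported as a limit too. The estimated step is a number no higher from compound 3 to compound 4 (the limit leaves the size open). For compound 4 the estimated value is 50000 nM, with an expected range from 20000 nM to 100000 nM.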

Compound 4, half-maximal effective concentration: 45000 nM
Compound 4: the middle estimate sits 1.1-fold (0.05 log units) above what was measured; the range from low to high includes it.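

In this assay compound 3 gives > 50000 nM as a limit of the assay, not a number. Putting 4-methylcyclohexyl in place of cyclohexylmethyl on the amide-type nitrogen only rearranges the same atoms, yet it gives an at least 1.1-fold lower number from compound 3 to compound 4 (0.04 log units; that floor lies within the scatter) and brings this pair onto the measurable part of the scale, which shows that this position can tolerate such a reshuffle without any sign of a higher number. Only the floor of that step is known, and it cannot be called a real change, because compound 3 sits at a limit: the limit of > 50000 nM in this assay, at which 2 of the 4 values shown sit.

The compounds shown leave open whether the reading goes with the methyl on the ring or with the ring sitting directly on the nitrogen, a question that a plain cyclohexyl group on that nitrogen would help to separate. As far as these compounds go, how a longer chain such as cyclohexylethyl, or a ring carrying an amine or a carboxylic acid, would read at this nitrogen also remains open.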